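Moving the Chlorine on a Phenyl Ring

A few compounds are considered here, and "the series" means these few. Any claim that something is new, unique, unknown or untested is made for them only; others in the source may bear on it.

Compound 1 `CC1=CC[C@@H]([C@@](C)(O)CCCC(C)(C)NC(=S)N/N=C\c2ccc(N(C)C)cc2)CC1` gives only a limit in a functional assay on HT-29 cells (Homo sapiens) for cytotoxicity, read by sulforhodamine B assay (a lower number here means a stronger inhibitor of growth, a higher number a weaker inhibitor of growth), > 100000 nM. For the measured compounds named here, compound 2 `CC1=CC[C@@H]([C@@](C)(O)CCCC(C)(C)NC(=S)N/N=C\c2cccc(Cl)c2)CC1` gives 16500 nM, the only actual number so far in this assay. Going by the values given here, the one measured step, an at least 6.0-fold lower number from compound 1 to compound 2 (0.78 log units; beyond the scatter), exchanged one group for a quite different one and rests on the limit in the limit of > 100000 nM in this assay, at which 1 of the 2 values shown sits. Compound 3 `CC1=CC[C@@H]([C@@](C)(O)CCCC(C)(C)NC(=S)N/N=C\c2ccc(Cl)cc2)CC1` instead has 4-chlorophenyl in place of 3-chlorophenyl on a carbon with a double bond to nitrogen. With the same atoms kept, the expected step in this assay is small, a 1.0-fold lower number from compound 2 to compound 3 (0.01 log units; within the scatter), within the usual scatter. For compound 3 the estimated value is 16000 nM, with an expected range from 6000 nM to 45000 nM.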

Compound 3, concentration for total growth inhibition: 22600 nM
For compound 3 the middle estimate is 1.4-fold (0.15 log units) below the measured one; the measured number falls inside the stated range.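

Putting 4-chlorophenyl in place of 3-chlorophenyl on the same carbon gives, in this assay, a 1.4-fold higher number from compound 2 to compound 3 (0.14 log units; within the scatter), so this move of the chlorine does not separate the two compounds. Chloro in place of dimethylamino on an aromatic carbon gives an at least 4.4-fold lower number from compound 1 to compound 3 (0.64 log units; beyond the scatter), so the chlorine compounds on either placement read lower than compound 1. That comparison rests on a limit: the limit of > 100000 nM in this assay, at which 1 of the 3 values shown sits. Still open, on these data alone, is how an unsubstituted phenyl ring, or a methoxy or nitrile group in the chlorine's place, would read in this assay.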